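Oxan-4-yl in place of 4-hydroxyphenyl: tolerability at the limit

A few compounds are considered here, and "the series" means these few. Any claim that something is new, unique, unknown or untested is made for them only; others in the source may bear on it.

Measured compounds and their values in a toxicity assay on THP-1 cells (Homo sapiens) for inhibition; a lower number here means that less compound is tolerated, a higher number that more compound is tolerated:
Compound 1 `COc1ccc(-c2cnc(NC(=O)c3ccc(O)cc3)n2C)cc1` gives > 100000 nM, which is a limit of the assay rather than a number.
Compound 2 `COc1ccc2c(c1)nc(NC(=O)c1ccc(F)cc1)n2C` gives > 100000 nM, again a limit.
Compound 3 `COc1ccc(-c2cnc(NC(=O)c3ccc([N+](=O)[O-])cc3)n2C)cc1` gives > 100000 nM, also a limit.

Compound 1 therefore stands only at a limit in this assay, and the two other values shown are limits as well, so no ranking among the three is possible. Within the data shown here, the one measured step that changes a single place, a step that the two limits leave unreadable from compound 1 to compound 3, is left unreadable by the two limits, and its size cannot be told. The unmeasured compound 4 `COc1ccc(-c2cnc(NC(=O)C3CCOCC3)n2C)cc1` differs from compound 1 by oxan-4-yl in place of 4-hydroxyphenyl on a carbonyl carbon. Among the measured compounds shown here, no measured step bears on this change in a readable way because the limit of > 100000 nM in this assay, at which 3 of the 3 values shown sit, leaves every step unreadable. Compound 4 is accordingly expected to sit at the same limit, most likely with no step beyond the scatter. Compound 4 is estimated at 100000 nM, with a range from 50000 nM to 300000 nM. The step this estimate implies, a number no higher from compound 1 to compound 4 (the limit leaves the size open), is expected to show nothing beyond the scatter.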

Compound 4, half-maximal cytotoxic concentration: > 100000 nM
Compound 4 was reported as a limit (the forecaster's own chance of this, stated with the estimate: 85%); the middle value lies on the limit itself.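

Going from compound 1 to compound 4, with oxan-4-yl in place of 4-hydroxyphenyl, gives no step that can be read, because both compounds stand at a limit rather than a number: the limit of > 100000 nM in this assay, at which 4 of the 4 values shown sit. Still open, from the compounds shown here alone, is whether these four compounds differ at all in this assay and at what concentration each would become toxic.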